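The source may hold more compounds than are shown below. What is called first, only, known or untested is meant among the compounds shown, and "the series" means these compounds.

Three amides built on one shared core differ only in the aryl group attached to the carbonyl carbon. Compound 1 `Cc1ccc(C(=O)Nc2cccc(-c3oc4cc(-c5ccc(F)cc5)ccc4c(=O)c3O)c2)cc1` carries a 4-methylphenyl group, compound 2 `COc1ccccc1C(=O)Nc1cccc(-c2oc3cc(-c4ccc(F)cc4)ccc3c(=O)c2O)c1` a 2-methoxyphenyl group, and compound 3 `Cc1cc(C(=O)Nc2cccc(-c3oc4cc(-c5ccc(F)cc5)ccc4c(=O)c3O)c2)ccc1F` a 4-fluoro-3-methylphenyl group. In a functional assay on GTL 16 cells for antiproliferative activity against GTL 16 cell line (Homo sapiens), read by CCK-8 assay, with a stated time of 72 h (on this read-out lower numbers stand for stronger inhibition and higher numbers for weaker inhibition), compound 1 gives 12900 nM, compound 2 gives 6370 nM, and compound 3 gives 12100 nM. The step of a 2.0-fold lower number from compound 1 to compound 2 (0.31 log units; beyond the scatter) is the only one that clears the scatter; a 1.1-fold lower number from compound 1 to compound 3 (0.03 log units; within the scatter) and a 1.9-fold higher number from compound 2 to compound 3 (0.28 log units; within the scatter) do not. Compound 2 thus has the lowest number of the three, though its gap to compound 3 is within the scatter, so the three compounds sit close together.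

Compound 4 `O=C(Nc1cccc(-c2oc3cc(-c4ccc(F)cc4)ccc3c(=O)c2O)c1)c1ccc(Cl)nc1` is not yet measured. It differs from compound 2 in one place: 6-chloropyridin-3-yl in place of 2-methoxyphenyl on a carbonyl carbon. The two earlier exchanges of the aryl group on the carbonyl carbon, a 2.0-fold lower number from compound 1 to compound 2 (0.31 log units; beyond the scatter) and a 1.9-fold higher number from compound 2 to compound 3 (0.28 log units; within the scatter), were small, so this read-out appears tolerant of such changes. The estimated step of a 1.4-fold higher number from compound 2 to compound 4 (0.15 log units; within the scatter) is expected to be modest, leaning toward a somewhat higher number because compound 2 already has the lowest value at 6370 nM. Compound 4 is therefore expected to give about 9000 nM, with a likely range of 4000 nM to 20000 nM.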

Compound 4, half-maximal inhibitory concentration: 7520 nM
Beside the measured number, compound 4's estimate is 1.2-fold (0.08 log units) above it; measured number inside the range.
By their numbers in this assay, from the lowest: compounds 2, 4, 3 and 1 (each within the scatter of the next, the first and the last beyond it).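

The new step shows that this position, on a carbonyl carbon whose other neighbour is an amide-type nitrogen, also accepts an aromatic ring with a hetero atom: in this assay the exchange of 2-methoxyphenyl for 6-chloropyridin-3-yl gives a 1.2-fold higher number from compound 2 to compound 4 (0.07 log units; within the scatter). The exchanges against the other two aryl groups, a 1.6-fold lower number from compound 3 to compound 4 (0.21 log units; within the scatter) and a 1.7-fold lower number from compound 1 to compound 4 (0.23 log units; within the scatter), also stay within the scatter, so the ring with a hetero atom cannot be told apart from the three rings of carbon only, and the pair of compound 1 and compound 2 remains the only one separated beyond it. Nothing shown here explains why the values stay so close.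

All four groups at this place are six-membered aromatic rings, which leaves open whether the same tolerance would hold for an amine such as piperidine, a carboxylic acid or a longer alkyl chain. As far as these compounds go, it also remains open what the ring nitrogen and the chlorine each contribute, a question that pyridin-3-yl without the chlorine could help to separate.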